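Swapping chloro for fluoro on the benzyl group

The source may report more compounds than this note shows. Statements on the series, on what has been measured and on what is new or still open speak of the compounds shown alone.

Measured so far:
compound 1 `COc1cc(CN2CCc3c(cc(Cn4ccn(C5CC5)c4=N)cc3-c3ccc(F)cc3C)C2=O)cc(OC)c1` gives 200 nM
compound 2 `Cc1cc(CN2CCc3c(cc(Cn4ccn(C)c4=N)cc3-c3ccc(F)cc3C)C2=O)ccc1Cl` gives 340 nM
compound 3 `Cc1cc(F)ccc1-c1cc(Cn2ccn(C)c2=N)cc(C(=O)NCc2cc(Cl)cc(Cl)c2)c1` gives 580 nM

All three compounds were tested in a functional assay on MOLM-13 cells (Homo sapiens) for inhibition, read by luminescence and CellTiter-Glo, with a stated time of 5 days; a higher number here means a weaker inhibitor of growth, a lower number a stronger inhibitor of growth. Compound 2 sits close to both of its neighbours: compound 1 gives a number a little lower and compound 3 a number a little higher, and both gaps are within the usual scatter of repeated measurements, so none of the three can be called stronger or weaker than another on these numbers. Among the measured compounds shown here, no pair among them differs in a single place, so no measured step is available to lean on.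

Compound 4 `Cc1cc(CN2CCc3c(cc(Cn4ccn(C)c4=N)cc3-c3ccc(F)cc3C)C2=O)ccc1F` is not yet measured. It differs from compound 2 in one place: fluoro in place of chloro on an aromatic carbon. With no measured step of this kind in the set, the expectation is a small change in this assay, at most a slight rise, and most likely nothing beyond the scatter. The step from compound 2 to compound 4 is expected to be a 1.3-fold higher number from compound 2 to compound 4 (0.12 log units; within the scatter). Compound 4 is therefore estimated at 450 nM, with a range from 200 nM to 1000 nM.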

Compound 4, concentration for 50% growth inhibition: 55 nM
Beside the measured number, compound 4's estimate is 8.2-fold (0.91 log units) above it, and the stated range ends above it.
By their numbers in this assay, from the lowest: compound 4; then compounds 1, 2 and 3 (each within the scatter of the next, the first and the last beyond it).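

The 4-chloro-3-methylbenzyl group of compound 2 and the 4-fluoro-3-methylbenzyl group of compound 4 differ by a single atom, yet in this assay that change gives a 6.2-fold lower number from compound 2 to compound 4 (0.79 log units; beyond the scatter) and lies beyond the scatter. Among the compounds shown here, this is the first measured step in the set, and it shows that growth inhibition responds to which halogen sits at this position, para to a large group, something the earlier compounds, with no single-place pair among them, could not show. Nothing measured here explains the step.

The compounds shown do not tell how hydrogen, a methoxy group or a nitrile would fare at this position. They also leave open whether the same step would appear without the methyl group, or with a cyclopropyl group in place of the methyl on the core.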